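The compounds below may be only part of what the source reports. "The series", "measured", "known", "first", "only" and "open" are said of these compounds alone.

Compound 1 `CCOC(=O)c1sc2cc(Oc3ccccc3)ccc2c1C`: 47600 nM
Compound 2 `CCOC(=O)c1cc2ccc(OC)cc2s1`: 44400 nM
Compound 3 `CCOC(=O)c1sc2cc(OC)ccc2c1C`: not yet measured

In an ADME assay on HeLa cells (Homo sapiens) for cytotoxicity, read by MTT assay, with a stated time of 2 days (on this read-out higher numbers stand for lower toxicity in this test and lower numbers for higher toxicity in this test), compound 2 gives 44400 nM, and this lies within the scatter of compound 1 at 47600 nM. Both numbers therefore sit at one level, and the series shows no spread beyond the scatter so far.

Compound 3 differs from compound 2 by methyl in place of hydrogen on an aromatic carbon, next to the ring atom that bears an ethoxycarbonyl group (methyl in place of hydrogen on an aromatic carbon). Among the compounds with values here, no pair of measured compounds shows this change, so the data give no direct guide to its size or direction in this assay. The expected result is no shift beyond the scatter. The estimated step of a 1.0-fold higher number from compound 2 to compound 3 (0.01 log units; within the scatter) reflects this. For compound 3 the expected value is 45000 nM, with an estimated range of 20000 nM to 95000 nM.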

Compound 3, half-maximal cytotoxic concentration: > 100000 nM
Compound 3: a limit, no number; the forecaster's own chance of this, stated with the estimate: 15%; middle value at least 2.2-fold (0.34 log units) from the limit.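

In this assay, methyl in place of hydrogen on an aromatic carbon, next to the ring atom that bears an ethoxycarbonyl group, gives an at least 2.2-fold higher number from compound 2 to compound 3 (0.35 log units; beyond the scatter), the first sign that this position affects the read-out, towards lower toxicity in this test. With that methyl present, the group on the oxygen also matters: methyl in place of phenyl on an oxygen on an aromatic ring gives an at least 2.1-fold higher number from compound 1 to compound 3 (0.32 log units; beyond the scatter), a difference that compounds 1 and 2, at one level with each other, did not reveal. Compound 3 gives a limit and not a number, so the full size of both steps stays unknown: the limit of > 100000 nM in this assay, at which 1 of the 3 values shown sits.

Going by these compounds, whether an ethyl group or a longer chain at this position would act as methyl does remains open. The compounds shown also leave open what a carboxylic acid or an amide in place of the ethoxycarbonyl group would give.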